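Working notes on the step from compound 3 to compound 4

The source may report more compounds than this note shows. Statements on the series, on what has been measured and on what is new or still open speak of the compounds shown alone.

The three measured compounds share one core and are read in a functional assay on NCI-H1975 cells (Homo sapiens) for inhibition, read by MTT assay, with a stated time of 72 h; a lower number here means a stronger inhibitor, a higher number a weaker inhibitor. Compound 1 `O=C(CSc1nc(Nc2ccccc2)c2ccccc2n1)Nc1ccc(F)cc1` gives 16500 nM. For the measured compounds named here, compound 2 `O=C(CSc1nc(Nc2ccccc2)c2ccccc2n1)Nc1ccc(Br)cc1` gives 10600 nM, the only one-place step in the set being a 1.6-fold lower number from compound 1 to compound 2 (0.19 log units; within the scatter). Compound 3 `C=CC(=O)Nc1cccc(NC(=O)CSc2nc(Nc3cccc(Br)c3)c3ccccc3n2)c1` carries an acrylamide and a bromo group elsewhere and gives 12100 nM; its value sits within the scatter of compound 2 and also of compound 1, so the three numbers cannot be ordered with any confidence.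

Compound 4 `C=CC(=O)Nc1cccc(NC(=O)CSc2nc(Nc3cc(OC)c(OC)c(OC)c3)c3ccccc3n2)c1` differs from compound 3 in one place: 3,4,5-trimethoxyphenyl in place of 3-bromophenyl on a nitrogen on an aromatic ring. Going by the values given here, no measured step touches the group on this nitrogen, and none introduces methoxy groups anywhere. Among the compounds with values here, the one step that exists, a 1.6-fold lower number from compound 1 to compound 2 (0.19 log units; within the scatter), concerns a halogen at a different place and stays within the scatter, so it offers little guidance on a change this large. With that thin basis, the expected step in this assay is a 1.0-fold lower number from compound 3 to compound 4 (0.00 log units; within the scatter), with a wide range around it to reflect the unsupported nature of the change. For compound 4 the estimate in this assay is therefore 12000 nM, expected to fall between 4000 nM and 40000 nM.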

Compound 4, half-maximal inhibitory concentration: > 50000 nM
Compound 4 was reported as a limit; the forecaster's own chance of this, stated with the estimate: 10%; middle value at least 4.1-fold (0.61 log units) from the limit.
By their numbers in this assay, from the lowest: compounds 2, 3 and 1 (each within the scatter of the next). At a limit, above all of these: compound 4.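

Compound 4 is reported in this assay as a limit and not as a number: the limit of > 50000 nM in this assay, at which 1 of the 4 values shown sits.

For the compounds shown here, the step, an at least 4.1-fold higher number from compound 3 to compound 4 (0.61 log units; beyond the scatter), is the only one in the set that lies beyond the scatter, and it is the only one that touches the group on the nitrogen on an aromatic ring. Going by these compounds alone, the earlier step, a 1.6-fold lower number from compound 1 to compound 2 (0.19 log units; within the scatter), changed a halogen at a different place and stayed within the scatter, so the earlier compounds gave no sign that the series responds to any change; this result shows that, in this assay, the position on this nitrogen does not tolerate every aryl group, since 3,4,5-trimethoxyphenyl, with its larger count of heavy atoms and its hydrogen-bond acceptors, gives a clearly higher number than 3-bromophenyl.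

From the compounds shown here alone, whether this shift comes from the number of methoxy groups, from their placement or from the loss of the bromine remains open, and a single methoxy group, a methyl group or an amine on this ring would help to separate these readings. Going by these compounds, how far the number rises beyond the limit also stays unknown, so the true size of the step remains open.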